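The source may report more compounds than this note shows. Statements on the series, on what has been measured and on what is new or still open speak of the compounds shown alone.

Compound 1 `COC(=O)CC/C=C\CC[C@H]1C(=O)C[C@@H](O)[C@@H]1/C=C/C[C@@](C)(O)/C=C/C1=CCCC1` is the reference point of the series. In a functional assay on the whole organism with Rattus norvegicus as the target (on this read-out lower numbers stand for an effect already at smaller amounts and higher numbers for an effect only at larger amounts of compound), compound 1 gives only a limit, > 3.16 mg/kg, and no number. Compound 2 `C=C/C(C)=C/[C@](C)(O)C/C=C/[C@H]1[C@H](O)CC(=O)[C@@H]1CC/C=C\CCC(=O)OC` differs from compound 1 by 2-methylbuta-1,3-dien-1-yl in place of 2-(cyclopent-1-en-1-yl)ethenyl, and in this assay compound 2 gives 1.03 mg/kg. That step, an at least 3.0-fold lower number from compound 1 to compound 2 (0.48 log units; beyond the scatter), is the only measured one, and its size is known only as a bound because of the limit of > 3.16 mg/kg in this assay, at which 1 of the 2 values shown sits.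

Compound 3 `C/C=C/C=C/[C@](C)(O)C/C=C/[C@H]1[C@H](O)CC(=O)[C@@H]1CC/C=C\CCC(=O)OC` is not yet measured. Its change from compound 1 reads (prop-1-en-1-yl in place of cyclopent-1-en-1-yl on a double-bonded chain carbon bound to a double-bonded chain carbon), again a ring leaving and an open chain entering, as in compound 2. For the measured compounds named here, the one step that bears on it, an at least 3.0-fold lower number from compound 1 to compound 2 (0.48 log units; beyond the scatter), points to a lower number, so a step of similar size in the same direction is expected here. The estimate for compound 3 in this assay is 1.2 mg/kg, within 0.5 mg/kg to 3 mg/kg. This estimate means an expected step of an at least 2.6-fold lower number from compound 1 to compound 3 (0.42 log units; beyond the scatter).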

Compound 3, dose for half-maximal effect: 0.25 mg/kg
The estimate for compound 3 lay 4.8-fold (0.68 log units) above the measured number; the measured number lies below the stated range.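

Two open-chain groups can now be compared at this place, and their arrangement matters beyond the scatter: penta-1,3-dien-1-yl in place of 2-methylbuta-1,3-dien-1-yl gives a modest further gain in this assay (a 4.1-fold lower number from compound 2 to compound 3 (0.61 log units; beyond the scatter)). For the compounds shown here, the loss of cyclopent-1-en-1-yl in favour of prop-1-en-1-yl therefore gives a large step, larger than the one seen with compound 2 (an at least 12-fold lower number from compound 1 to compound 3 (1.10 log units; beyond the scatter)). Both steps from compound 1 are known only as bounds, because compound 1 gives a limit and no number: (the limit of > 3.16 mg/kg in this assay, at which 1 of the 3 values shown sits).

Going by these compounds, whether the gain depends on the second double bond remains open, as a saturated pentyl chain would test this. Also open, on these data alone, is whether a longer chain such as hepta-1,3-dien-1-yl, or a phenyl group, would hold the number of compound 3.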